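Working notes: replacing the six-membered ring of compound 1

The source may hold more compounds than are shown below. What is called first, only, known or untested is meant among the compounds shown, and "the series" means these compounds.

Measured in a functional assay on MCF7 cells (Homo sapiens) for antiproliferative activity; on this read-out lower numbers stand for stronger inhibition of growth and higher numbers for weaker inhibition of growth:
- compound 1 `CC/C=C\[C@H](C)[C@H](OC(N)=O)[C@@H](C)[C@H](O)[C@@H](C)C/C(C)=C\[C@H](C)[C@@H](O)[C@@H](C)/C=C\[C@@H](O)C[C@@H]1OC(=O)[C@H](C)C[C@H]1C`: 5.8 nM
- compound 2 `CC/C=C\[C@H](C)[C@H](OC(N)=O)[C@@H](C)[C@H](O)[C@@H](C)C/C(C)=C\[C@H](C)[C@@H](O)[C@@H](C)/C=C\[C@@H](O)C[C@H](O)[C@H](C)C[C@H](C)C(=O)OC`: 1000 nM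
- compound 3 `CC/C=C\[C@H](C)[C@H](OC(N)=O)[C@@H](C)[C@H](O)[C@@H](C)C/C(C)=C\[C@H](C)[C@@H](O)[C@@H](C)/C=C\[C@@H](O)C[C@@H]1OC(=O)[C@H](C)[C@@H](O)[C@H]1C`: 6.2 nM

Compound 1 and compound 3 sit together at the low end of these numbers, and compound 2 stands far from both. Compound 4 `CC/C=C\[C@H](C)[C@H](OC(N)=O)[C@@H](C)[C@H](O)[C@@H](C)C/C(C)=C\[C@H](C)[C@@H](O)[C@@H](C)/C=C\[C@H](O)C[C@@H]1CCC(=O)O1` is not yet measured and differs from compound 1 as follows: a group of 9 heavy atoms (6 carbon, 3 oxygen; one five-membered non-aromatic ring with 1 hetero atom) in place of a group of 12 heavy atoms (9 carbon, 3 oxygen; one six-membered non-aromatic ring with 1 hetero atom), on a double-bonded chain carbon bound to a double-bonded chain carbon.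

Going by the values given here, three measured steps bear on this change. Hydroxy in place of hydrogen on a saturated ring carbon gave a 1.1-fold higher number from compound 1 to compound 3 (0.03 log units; within the scatter). Compound 2 has no ring in that group, and the two steps involving it are both large: a 170-fold higher number from compound 1 to compound 2 (2.24 log units; beyond the scatter) and a 160-fold lower number from compound 2 to compound 3 (2.21 log units; beyond the scatter). Among the compounds with values here, compound 4 keeps a ring, but no measured compound has the five-membered one, so the data do not cover this ring directly. Within the data shown here, a step towards a higher number is expected, smaller than the one seen with compound 2. In this assay the estimated step is a 12-fold higher number from compound 1 to compound 4 (1.08 log units; beyond the scatter). The estimate for compound 4 is 70 nM, with an expected range of 12 nM to 500 nM.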

Compound 4, concentration for 50% growth inhibition: 2000 nM
Beside the measured number, compound 4's estimate is 29-fold (1.46 log units) below it; measured number outside the range, above it.
By their numbers in this assay, from the lowest: compounds 1 and 3 (each within the scatter of the next); then compounds 2 and 4 (each within the scatter of the next).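

Keeping a ring in this group is not enough in this assay: the group of 9 heavy atoms with the five-membered non-aromatic ring gives a 340-fold higher number from compound 1 to compound 4 (2.54 log units; beyond the scatter). High numbers here are therefore not confined to the ring-free group of compound 2, since compound 4 lies within the scatter of it, while only compound 1 and compound 3, with their six-membered rings, stay at the low end. Nothing in hand gives a reason for this step.

The change alters ring size, heavy-atom count and defined stereocentres together, so the compounds shown do not separate these. A five-membered ring carrying methyl groups, or a six-membered ring without them, would be needed to tell whether ring size or the methyl groups decide the result.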